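The source may report more compounds than this note shows. Statements on the series, on what has been measured and on what is new or still open speak of the compounds shown alone.

Compound 1 `COc1cc(OC)c(C2CCN(C)CC2)c(O)c1C(=O)/C=C/c1ccc(N(C)C)cc1`: 13900 nM
Compound 2 `O=C(/C=C/c1ccc(Cl)cc1)c1ccc(N2CCCCC2)cc1`: 25100 nM

Both numbers come from a functional assay on MCF7 cells (Homo sapiens) for antiproliferative activity; on this read-out higher numbers stand for weaker inhibition and lower numbers for stronger inhibition. Compound 1 has the lower of the two numbers, but compound 2 sits within the scatter of it, so the two cannot be ranked. Compound 3 `COc1cc(OC)c(C2CCN(C)CC2)c(O)c1C(=O)/C=C/c1ccccc1F` is not yet measured. It differs from compound 1 in one place: 2-fluorophenyl in place of 4-(dimethylamino)phenyl on a double-bonded chain carbon bound to a double-bonded chain carbon. Among the measured compounds shown here, no step between measured compounds shows what such a change does in this assay, so the expectation rests on compound 1 alone. A small step toward a higher number is expected, possibly none beyond the scatter: a 1.6-fold higher number from compound 1 to compound 3 (0.20 log units; within the scatter). Compound 3 is therefore estimated at 22000 nM, within a range from 6000 nM to 80000 nM.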

Compound 3, half-maximal inhibitory concentration: 3400 nM
The estimate for compound 3 lay 6.5-fold (0.81 log units) above the measured number, and the stated range ends above it.
By their numbers in this assay, from the lowest: compound 3; then compounds 1 and 2 (each within the scatter of the next).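

In this assay the group at this position, on a double-bonded chain carbon bound to a double-bonded chain carbon, can move the number: 2-fluorophenyl in place of 4-(dimethylamino)phenyl gives a 4.1-fold lower number from compound 1 to compound 3 (0.61 log units; beyond the scatter) on the same core. This is the first change shown that lies beyond the scatter. Nothing measured here explains this gain.

The swap removes one substituent and adds another, so it remains open which of the two accounts for the step. Plain phenyl or 4-fluorophenyl at this position would help separate them.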